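A few compounds are considered here, and "the series" means these few. Any claim that something is new, unique, unknown or untested is made for them only; others in the source may bear on it.

Measured so far in a functional assay on HOS cells (Homo sapiens) for antiproliferative activity, read by sulforhodamine B assay; on this read-out higher numbers stand for weaker inhibition of growth and lower numbers for stronger inhibition of growth:
compound 1, `O[C@H]1CO[C@H](COCc2ccccc2)[C@@H](OCc2ccccc2)[C@@H]1OCc1ccccc1`, gives 37900 nM.
compound 2, `CCCCOC[C@H]1O[C@@H](CCC)[C@H](O)[C@@H](OCCCC)C1OCCCC`, gives only a limit of the assay, > 50000 nM.
compound 3, `CC(C)C[C@H]1O[C@H](COCc2ccccc2)[C@@H](OCc2ccccc2)[C@H](OCc2ccccc2)[C@H]1O`, gives 44500 nM.

Compound 1 has the lowest of the two numbers shown, with compound 3 within the scatter of it; one value sits at the limit of > 50000 nM in this assay, at which 1 of the 3 values shown sits.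

Compound 4, `O[C@@H]1[C@@H](OCc2ccccc2)[C@H](OCc2ccccc2)[C@@H](COCc2ccccc2)O[C@H]1CC1CCCCC1`, differs from compound 1 by cyclohexylmethyl in place of hydrogen on a saturated ring carbon. For the measured compounds named here, the one measured step that bears on this change is a 1.2-fold higher number from compound 1 to compound 3 (0.07 log units; within the scatter), an alkyl group entering at the same saturated ring carbon and leaving the number within the scatter. A cyclohexylmethyl group is therefore expected to behave alike, with no shift beyond the scatter in this assay. Compound 4 is expected to give about 45000 nM, between 20000 nM and 100000 nM. The expected step is a 1.2-fold higher number from compound 1 to compound 4 (0.07 log units; within the scatter).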

Compound 4, concentration for 50% growth inhibition: 4400 nM
Estimate against measurement, compound 4: 10-fold (1.01 log units) above; the whole stated range lies above it.
By their numbers in this assay, from the lowest: compound 4; then compounds 1 and 3 (each within the scatter of the next). At a limit, above all of these: compound 2.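

In this assay, this saturated ring carbon next to the ring oxygen turns out to be a place where a substituent can move the number: cyclohexylmethyl in place of hydrogen gives an 8.6-fold lower number from compound 1 to compound 4 (0.94 log units; beyond the scatter). Isobutyl at that carbon gave only a 1.2-fold higher number from compound 1 to compound 3 (0.07 log units; within the scatter), so an alkyl group there does not by itself bring a shift beyond the scatter. Nothing shown gives a cause for the step with cyclohexylmethyl.

As far as these compounds go, it remains open whether benzyl, a longer chain or an amine at this carbon would move the number as cyclohexylmethyl does.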